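The source may report more compounds than this note shows. Statements on the series, on what has been measured and on what is new or still open speak of the compounds shown alone.

Working notes on the urea series.

Compound 1 `COc1cc(NC(=O)Nc2cc(Nc3ccc(OC)c(C)c3)ncn2)cc(OC)c1` is the reference point here. In a functional assay on NCI-H1581 cells (Homo sapiens) for inhibition, read by MTT assay, with a stated time of 48 h, tested at 10 uM (a lower number here means less inhibition, a higher number more inhibition at the concentration tested (going by the name of the read-out)), compound 1 gives 19.7%, the lowest of the three numbers measured. Compound 2 `COc1cc(Br)ccc1Nc1cc(NC(=O)Nc2c(Cl)cccc2Cl)ncn1` gives 47.3%, and compound 3 `Cc1ccc(Nc2cc(NC(=O)Nc3c(Cl)cccc3Cl)ncn2)cc1C` gives 73.3%; both gaps to compound 1 lie beyond the scatter.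

For the measured compounds named here, the one measured step that changes the same part of the molecule is a number 26 percentage points higher from compound 2 to compound 3 (beyond the scatter). It shows that the aryl group on the amine nitrogen can move the read-out by a modest amount, and that the aryl carrying a 2-methoxy group sat on the lower side of that pair. Its urea partner differs from that of compound 1, so the step transfers only loosely.

Compound 4 `COc1cc(NC(=O)Nc2cc(Nc3cc(F)ccc3OC)ncn2)cc(OC)c1` is the next variation on compound 1: 5-fluoro-2-methoxyphenyl in place of 4-methoxy-3-methylphenyl on a nitrogen on an aromatic ring. The entering group, like that of compound 2, carries a 2-methoxy group, and compound 2 sat below compound 3. On that thin basis the expected step from compound 1 is a number 3.7 percentage points lower from compound 1 to compound 4 (within the scatter), small and not clearly beyond the scatter, with a slight lean downward. The estimate for compound 4 in this assay is therefore 16%, within 2% to 36%.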

Compound 4, a percentage reported as inhibition, at one concentration (the size of the read-out at that concentration, not a potency): 42.1%
Compound 4: middle estimate off by 26.1 percentage points, on the low side, and the stated range ends below it.
By their numbers in this assay, from the lowest: compound 1; then compounds 4 and 2 (each within the scatter of the next); then compound 3.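

In this assay the exchange on the nitrogen, a number 22.4 percentage points higher from compound 1 to compound 4 (beyond the scatter), shows that the aryl group at this place also moves the read-out on the urea partner of compound 1, whereas the earlier measured step at this place came only from the urea partner of compound 2 and compound 3. A 2-methoxy group on this aryl therefore does not go with the lower number in every pair: compound 2 sits below compound 3, but compound 4, which goes against that reading, sits above compound 1, so the direction of a change here cannot be told from that group alone. Nothing available explains the rise, and the step cannot be assigned to the fluorine, to the moved methoxy group or to the loss of the methyl group.

Going by these compounds, what stays open is how much of the step each of those three differences carries, and whether 5-fluoro-2-methoxyphenyl keeps its advantage over 4-methoxy-3-methylphenyl on the urea partner of compound 3. How this place responds to an aryl carrying a basic amine such as piperazine, or a carboxylic acid, also remains unknown from the compounds shown.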